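Aryl variation on the anilino nitrogen of the series

The source may hold more compounds than are shown below. What is called first, only, known or untested is meant among the compounds shown, and "the series" means these compounds.

Measured compounds:
compound 1 `COc1cc2ncnc(Nc3cccc(Cl)c3)c2cc1OCCCCC(=O)Nc1ccc(S(N)(=O)=O)cc1`: 30400 nM
compound 2 `COc1ccc(Nc2ncnc3cc(OC)c(OCCCCC(=O)Nc4ccc(S(N)(=O)=O)cc4)cc23)cc1OC`: 35400 nM

In a functional assay on A-431 cells (Homo sapiens) for antiproliferative activity, read by MTT assay, with a stated time of 72 h (a higher number here means a weaker inhibitor, a lower number a stronger inhibitor), compound 1 gives 30400 nM, and in the same assay compound 2 gives 35400 nM. For the measured compounds named here, these two numbers lie within the scatter of each other, so compound 2 stands level with compound 1, the only other measured member, and no order between them is drawn. Going by the values given here, the single measured step, a 1.2-fold higher number from compound 1 to compound 2 (0.07 log units; within the scatter), swaps the aryl group on the nitrogen on the aromatic ring and leaves the number where it was.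

Compound 3 `COc1cc2ncnc(Nc3cc(F)c(F)c(F)c3)c2cc1OCCCCC(=O)Nc1ccc(S(N)(=O)=O)cc1` is the next member. It differs from compound 2 in the same place: 3,4,5-trifluorophenyl in place of 3,4-dimethoxyphenyl on a nitrogen on an aromatic ring. Among the compounds with values here, the one step that bears on this change is the step from compound 1 to compound 2, which stayed within the scatter, so a change of the aryl group at this position has so far not moved the number. Within the data shown here, no measured step speaks to the fluorinated ring itself, so the expectation rests on that one step alone.

Compound 3 is therefore expected to give 32000 nM in this assay, with a range of 11000 nM to 95000 nM. The expected step is a 1.1-fold lower number from compound 2 to compound 3 (0.04 log units; within the scatter), none beyond the scatter.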

Compound 3, half-maximal inhibitory concentration: 23400 nM
For compound 3 the middle estimate is 1.4-fold (0.14 log units) above the measured one; the measured number falls inside the stated range.
By their numbers in this assay, from the lowest: compounds 3, 1 and 2 (each within the scatter of the next).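

In this assay, a third aryl group on the nitrogen on an aromatic ring again leaves the number in place: both new steps stay within the scatter (a 1.5-fold lower number from compound 2 to compound 3 (0.18 log units; within the scatter); a 1.3-fold lower number from compound 1 to compound 3 (0.11 log units; within the scatter)). For the compounds shown here, the earlier pair offered only one step at this position, whereas the three compounds now give three pairings, with no order among 3-chlorophenyl, 3,4-dimethoxyphenyl and 3,4,5-trifluorophenyl and no compound going against this level pattern; this holds even though 3,4-dimethoxyphenyl, with 2 hydrogen-bond acceptors, gives way to 3,4,5-trifluorophenyl, with 0. No supporting data are available to account for this level behaviour.

Open is whether this tolerance extends to aryl groups carrying an amine or a carboxylic acid, or to a non-aromatic group such as cyclohexyl on the same nitrogen, since all three compounds shown carry a substituted phenyl ring there. Also open, from the compounds shown here alone, is whether a longer chain in place of the one joining the shared core to the sulfonamide-bearing amide would move the number, and whether the aryl group would then begin to matter.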